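The source may report more compounds than this note shows. Statements on the series, on what has been measured and on what is new or still open speak of the compounds shown alone.

Measured so far:
compound 1 `N#Cc1ccc(N2CCC(C(=O)N3N=CC[C@H]3c3cc(F)cc(F)c3)CC2)nn1`: > 8 h
compound 2 `O=C(C1CCN(c2cccnn2)CC1)N1N=CC[C@H]1c1ccccc1`: 2.32 h
compound 3 `CC(C)(C)C(=O)N1CCC1c1ccccc1`: > 2.75 h

All three compounds were tested in an ADME assay on cells (Hepatocyte, Homo sapiens) for metabolic stability; on this read-out higher numbers stand for a longer-lived compound and lower numbers for a shorter-lived compound. Compound 2 gives 2.32 h in this assay, the only result here that is a plain number. For compound 1 the assay reports only a limit, > 8 h, which is the limit of > 8 h in this assay, at which 1 of the 3 values shown sits. For compound 3 the result is likewise a limit, > 2.75 h, which is the limit of > 2.75 h in this assay, at which 1 of the 3 values shown sits. Compound 1 thus stands at the upper edge of what this assay can report, with no exact number behind it. No two of these compounds differ in just one place, so no single step can be read from the measured set.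

Compound 4 `N#Cc1nccc(N2CCC(C(=O)N3N=CC[C@H]3c3cc(F)cc(F)c3)CC2)n1` has not yet been measured. It differs from compound 1 in one place: a group of 8 heavy atoms (5 carbon, 3 nitrogen; one six-membered aromatic ring with 2 hetero atoms) in place of a group of 8 heavy atoms (5 carbon, 3 nitrogen; one six-membered aromatic ring with 2 hetero atoms), on an amine nitrogen in a ring Both groups hold one six-membered aromatic ring with 2 hetero atoms and one triple bond outside aromatic rings, so the change is a rearrangement rather than an addition. Without a measured pair of this kind, the expected step of a number no higher from compound 1 to compound 4 (the limit leaves the size open) is small, within the usual scatter. Compound 4 is therefore estimated at 8 h, with a range from 3 h to 20 h.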

Compound 4, half-life: 2.1 h
Compound 4: the middle estimate sits 3.8-fold (0.58 log units) above what was measured; the whole stated range lies above it.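

Within the data shown here, this is the first single-place step in the set, and it shows that the group on the amine nitrogen of the six-membered non-aromatic ring matters for lifetime in this assay, even when the atoms stay the same. Rearranging that group into 2-cyanopyrimidin-4-yl gives an at least 3.8-fold lower number from compound 1 to compound 4 (0.58 log units; beyond the scatter), although both groups have the same counts of heavy atoms, hydrogen-bond donors and hydrogen-bond acceptors. The true size of this step stays unknown, because the result for compound 1 is a limit, not a number: the limit of > 8 h in this assay, at which 1 of the 4 values shown sits.

The compounds shown do not explain why the rearrangement shortens the half-life. They also leave open whether the same group change would have a similar effect on another core, and how a pyridine ring bearing a nitrile or a pyrimidine ring bearing a methoxy group would behave at this position.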